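This account rests on a few compounds, and the source may have more. Where it says the series, first, only, none or still open, it means among the compounds named here.

Measured so far:
compound 1, `COc1cc(N2C(N)=C(C#N)C(/C=C/c3ccccc3)C3=C2CC(C)(C)CC3=O)cc(OC)c1OC`: 30%
compound 2, `COc1cc(N2C(N)=C(C#N)C(c3c(OC)ccc4ccccc34)C3=C2CC(C)(C)CC3=O)cc(OC)c1OC`: 5%

In a functional assay on Ehrlich cells (Mus musculus) for cytotoxicity, tested at 25 ug/mL (a lower number here means a weaker effect, a higher number a stronger effect of the compound at the concentration tested), compound 1 gives 30%, the highest of the two numbers; its nearest neighbour is compound 2, which gives 5%. Among the measured compounds shown here, the one measured step, a number 25 percentage points lower from compound 1 to compound 2 (beyond the scatter), comes with 2-methoxynaphthalen-1-yl in place of 2-phenylethenyl on a saturated ring carbon.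

Compound 3, `COc1cc(N2C(N)=C(C#N)C(c3ccc(C)cc3)C3=C2CC(C)(C)CC3=O)cc(OC)c1OC`, is not yet measured. Against compound 1 the change is 4-methylphenyl in place of 2-phenylethenyl on a saturated ring carbon. For the measured compounds named here, this change sits on the same saturated ring carbon as the measured step and again swaps the 2-phenylethenyl group for an aromatic ring, so that step is the only guide. Because a number 25 percentage points lower from compound 1 to compound 2 (beyond the scatter) was a modest loss beyond the scatter, a loss of similar or somewhat smaller size is expected here, with a single data point leaving the size uncertain. For compound 3 the expected value in this assay is 15%, with a range from 0% to 35%. The step this estimate implies, a number 15 percentage points lower from compound 1 to compound 3 (beyond the scatter), is expected to reach beyond the scatter.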

Compound 3, a percentage reported as activity, at one concentration (the size of the read-out at that concentration, not a potency): 50%
Estimate against measurement, compound 3: 35 percentage points below; measured number outside the range, above it.
By their numbers in this assay, from the lowest: compound 2; then compound 1; then compound 3.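

In this assay, an aromatic ring in place of 2-phenylethenyl on this saturated ring carbon does not in itself lower the number: 4-methylphenyl gives a number 20 percentage points higher from compound 1 to compound 3 (beyond the scatter) in this series. The direction of the change therefore depends on which aromatic group enters, not merely on the removal of 2-phenylethenyl. The two aromatic groups also lie far apart, with a number 45 percentage points higher from compound 2 to compound 3 (beyond the scatter) on exchanging 2-methoxynaphthalen-1-yl for 4-methylphenyl, and no measurement at hand gives a reason for either step.

The compounds shown leave open whether the methyl group of 4-methylphenyl contributes to the higher number, which a plain phenyl group on the same carbon would test. Also open, as far as these compounds go, is how this carbon tolerates a non-aromatic substituent, such as a chain ending in an amine or a carboxylic acid.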